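A few compounds are considered here, and "the series" means these few. Any claim that something is new, unique, unknown or untested is made for them only; others in the source may bear on it.

Working notes on the series. Going by the values given here, compound 1 `CC(=O)NN(C)C(=O)NCc1ccccc1` is the one member with a number: in a functional assay on the whole organism with Mus musculus as the target, in the maximal electroshock model (on this read-out higher numbers stand for an effect only at larger amounts of compound and lower numbers for an effect already at smaller amounts), compound 1 gives 89 mg/kg. Compound 2 `CC(=O)NN(C(=O)NCc1ccccc1)c1ccccc1` carries phenyl in place of methyl on an amide-type nitrogen. In this assay compound 2 gives > 30 mg/kg, which is a limit of the assay and not a number. Compound 3 `CC(=O)NN(C(=O)NCc1ccccc1)c1ccccn1` carries pyridin-2-yl at the same nitrogen. In this assay compound 3 gives > 30 mg/kg, again a limit of the assay. Compound 3 therefore stands at the limit of > 30 mg/kg in this assay, at which 2 of the 3 values shown sit, and cannot be placed against compound 1 on a numerical scale.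

Compound 4 `CC(=O)NN(C(=O)NCc1ccccc1)c1ncccn1` is not yet measured. The change from compound 3 to compound 4 is pyrimidin-2-yl in place of pyridin-2-yl on an amide-type nitrogen. The steps that touch this position are a step that the limit leaves unreadable from compound 1 to compound 3 and a step that the two limits leave unreadable from compound 2 to compound 3; both are unreadable, so no size or direction can be drawn from them. No other evidence bears on the change. In this assay compound 4 is expected near 60 mg/kg, between 20 mg/kg and 200 mg/kg, with a step that the limit leaves unreadable from compound 3 to compound 4 expected, most likely reported again as a limit.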

Compound 4, dose for half-maximal effect: > 100 mg/kg
Compound 4 was reported as a limit (the forecaster's own chance of this, stated with the estimate: 70%); middle value at least 1.6-fold (0.22 log units) from the limit.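

In this assay compound 4 is again reported as a limit of the assay and not a number: the limit of > 100 mg/kg in this assay, at which 1 of the 4 values shown sits. Pyrimidin-2-yl in place of methyl on this amide-type nitrogen gives an at least 1.1-fold higher number from compound 1 to compound 4 (0.05 log units; that floor lies within the scatter), the first step at this position that can be read, though only as a floor and not as a size. The steps among compound 2, compound 3 and compound 4 cannot be read, so the second ring nitrogen of pyrimidin-2-yl has no readable effect against pyridin-2-yl.

The compounds shown leave open whether any aromatic ring at this nitrogen gives a number in this assay. They also leave open how a longer chain such as propyl, or an amine such as dimethylamino, would compare with the methyl of compound 1.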